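The compounds below may be only part of what the source reports. "The series", "measured", "known", "first", "only" and "open" are said of these compounds alone.

Within the data shown here, in a functional assay on MCF7 cells (Homo sapiens) for antiproliferative activity, with a stated time of 72 h (a higher number here means a weaker inhibitor, a lower number a stronger inhibitor), compound 1 `COC(=O)CN(C)Cc1c(OC)cc(OC)c(C(=O)/C=C/c2ccccc2Cl)c1O` gives 10600 nM and so stands highest of the two numbers so far, with compound 2 `COc1cc(OC)c(C(=O)/C=C/c2ccccc2Cl)c(O)c1CN1CCCC1` at 3900 nM as its only neighbour. Compound 3 `COc1cc(OC)c(C(=O)/C=C/c2ccccc2Cl)c(O)c1CN1CCCCC1` differs from compound 1 in having piperidin-1-yl in place of ((methoxycarbonyl)methyl)(methyl)amino on a saturated chain carbon bound to an aromatic carbon. Among the measured compounds shown here, the one measured step that bears on this (a 2.7-fold lower number from compound 1 to compound 2 (0.43 log units; beyond the scatter)) is modest but beyond the scatter and brings pyrrolidin-1-yl to the same place, so a step of similar size toward a lower number is expected in this assay as well. The estimated step (a 2.4-fold lower number from compound 1 to compound 3 (0.37 log units; beyond the scatter)) is of that kind. Compound 3 is estimated at 4500 nM with 1800 nM to 10000 nM as the expected range.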

Compound 3, half-maximal inhibitory concentration: 2600 nM
The estimate for compound 3 lay 1.7-fold (0.24 log units) above the measured number, within the range that was stated.
By their numbers in this assay, from the lowest: compounds 3 and 2 (each within the scatter of the next); then compound 1.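

In this assay, piperidin-1-yl also beats ((methoxycarbonyl)methyl)(methyl)amino on the saturated chain carbon bound to an aromatic carbon, giving a 4.1-fold lower number from compound 1 to compound 3 (0.61 log units; beyond the scatter), so the earlier gain now holds for two ring amines. The two rings cannot be told apart in this assay (a 1.5-fold lower number from compound 2 to compound 3 (0.18 log units; within the scatter)), so this change in ring size shows no clear effect. Nothing measured here explains these steps.

As far as these compounds go, it remains open whether the ring itself matters or only the loss of the methoxycarbonyl group. Dimethylamino, an open amine without the ester, could separate these two readings, while morpholin-4-yl would test another ring.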